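Removing Both Chlorines From the Benzamide Ring

The source may report more compounds than this note shows. Statements on the series, on what has been measured and on what is new or still open speak of the compounds shown alone.

Compound 1 `COc1cc(/C=C/C(=O)c2cccc(NC(=O)c3cc(Cl)cc(Cl)c3)c2)ccc1O` is one of three analogues that share a core and differ only in the aryl group on the carbonyl carbon of the amide. In a functional assay on B16 cells (Mus musculus) for inhibition (on this read-out higher numbers stand for weaker inhibition and lower numbers for stronger inhibition), compound 1 gives 4.83 ug/mL, the second highest of the three numbers. Compound 2 `COc1cc(/C=C/C(=O)c2cccc(NC(=O)c3ccc(Cl)cc3)c2)ccc1O` gives 0.59 ug/mL, and compound 3 `COc1cc(/C=C/C(=O)c2cccc(NC(=O)c3ccc(Cl)cc3Cl)c2)ccc1O` gives 12.8 ug/mL. The step of an 8.2-fold lower number from compound 1 to compound 2 (0.91 log units; beyond the scatter) shows that taking away one of the two chlorines lowers the number well beyond the scatter, while a 22-fold higher number from compound 2 to compound 3 (1.34 log units; beyond the scatter) shows that adding a chlorine raises it sharply; a 2.7-fold higher number from compound 1 to compound 3 (0.42 log units; beyond the scatter) points the same way.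

Compound 4 `COc1cc(/C=C/C(=O)c2cccc(NC(=O)c3ccccc3)c2)ccc1O` has not been measured in this assay. It differs from compound 1 in that (phenyl in place of 3,5-dichlorophenyl on a carbonyl carbon). Among the compounds with values here, since both chlorines leave, the step from compound 1 to compound 2 bears most directly on it, and a modest drop in the number is expected, though with no measured phenyl analogue the size is uncertain. Compound 4 is therefore estimated at 1.5 ug/mL, expected between 0.4 ug/mL and 6 ug/mL, meaning an expected step of a 3.2-fold lower number from compound 1 to compound 4 (0.51 log units; beyond the scatter).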

Compound 4, half-maximal inhibitory concentration: 0.82 ug/mL
Compound 4: the middle estimate sits 1.8-fold (0.26 log units) above what was measured; low and high end bracket the measured number.
By their numbers in this assay, from the lowest: compounds 2 and 4 (each within the scatter of the next); then compound 1; then compound 3.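

In this assay, phenyl on the carbonyl carbon gives a 5.9-fold lower number from compound 1 to compound 4 (0.77 log units; beyond the scatter) and a 16-fold lower number from compound 3 to compound 4 (1.19 log units; beyond the scatter), so neither dichlorophenyl group is needed for a low number among these compounds. The remaining step, a 1.4-fold higher number from compound 2 to compound 4 (0.14 log units; within the scatter), lies within the scatter: compound 2 and compound 4 cannot be told apart, and the drop seen on going from 3,5-dichlorophenyl to 4-chlorophenyl is not carried further when the last chloro gives way to hydrogen. Nothing measured here accounts for these steps.

The compounds shown leave open whether a methoxy, hydroxyl or amine on this phenyl would keep the number close to that of compound 4. They also leave open how the number would respond to a cyclohexyl or a longer alkyl chain in place of the phenyl.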